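The source may report more compounds than this note shows. Statements on the series, on what has been measured and on what is new or still open speak of the compounds shown alone.

Compound 1 `COc1cc(C(c2ccc(O)c(OC)c2)[C@H](C)[C@@H](C)CF)ccc1O` and compound 2 `COc1cc(C(c2ccc(O)c(OC)c2)[C@@H](C)[C@H](C)CF)ccc1O` are mirror images. In a functional assay on HL-60 cells (Homo sapiens) for cytotoxicity, read by WST assay, with a stated time of 48 h (a higher number here means a weaker inhibitor, a lower number a stronger inhibitor), compound 1 gives 45000 nM and compound 2 gives 32000 nM; the step of a 1.4-fold lower number from compound 1 to compound 2 (0.15 log units; within the scatter) rests only on (the fact that compounds 1 and 2 differ only in the configuration as drawn). Compound 2 stands at the lowest of the two numbers, with compound 1 nearest and within the scatter. Compound 3 `COC[C@H](C)[C@@H](C)C(c1ccc(O)c(OC)c1)c1ccc(O)c(OC)c1` carries 2-(methoxymethyl)-1-methylpropyl in place of 2-(fluoromethyl)-1-methylpropyl on a saturated chain carbon bound to two aromatic carbons. Among the measured compounds shown here, no measured step covers this change; the single step of a 1.4-fold lower number from compound 1 to compound 2 (0.15 log units; within the scatter) concerns configuration alone and lies within the scatter, so no step beyond the scatter is expected in this assay. Compound 3 is expected to give 32000 nM, within 10000 nM to 100000 nM. The expected step is no change at the digits printed from compound 2 to compound 3 (within the scatter).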

Compound 3, half-maximal inhibitory concentration: 68000 nM
Estimate against measurement, compound 3: 2.1-fold (0.33 log units) below; the measured number falls inside the stated range.
By their numbers in this assay, from the lowest: compounds 2, 1 and 3 (each within the scatter of the next, the first and the last beyond it).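

In this assay, a change of group at this chain end can now be read alongside the mirror-image pair: a 2.1-fold higher number from compound 2 to compound 3 (0.33 log units; beyond the scatter) stands beyond the scatter, while a 1.5-fold higher number from compound 1 to compound 3 (0.18 log units; within the scatter) stays within it. The effect of methoxy-bearing compound 3 therefore depends on the comparison: it separates from compound 2 but not from compound 1. The data shown give no reason for that gap.

Going by these compounds, whether a hydroxyl, an amine or a longer chain at this chain end would move the number further stays open.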